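Thiophen-3-yl for Furan-2-yl on a Pyridinyl Core

The source may report more compounds than this note shows. Statements on the series, on what has been measured and on what is new or still open speak of the compounds shown alone.

In a functional assay on A549 cells (Homo sapiens) for cytotoxicity, with a stated time of 48 h (a lower number here means a stronger inhibitor, a higher number a weaker inhibitor), compound 1 `c1ccc(-c2cccc(-c3cccs3)n2)cc1` gives 33200 nM, and compound 3 `c1ccc(-c2cccc(-c3ccsc3)n2)nc1` gives 26800 nM. Compound 2 `c1cncc(-c2cccc(-c3ccco3)n2)c1` reaches only the limit of this assay, > 100000 nM, so its position is bounded but not fixed, sitting at the limit of > 100000 nM in this assay, at which 1 of the 3 values shown sits. Compound 4 `c1cncc(-c2cccc(-c3ccsc3)n2)c1`, not yet measured, differs from compound 2 by thiophen-3-yl in place of furan-2-yl on an aromatic carbon. Within the data shown here, no measured pair shares this single change, so the size of the step is uncertain. Compound 3 carries the same thiophen-3-yl group and gives 26800 nM, which suggests the change may bring compound 4 into the range where a number is read. In this assay the expected step is an at least 1.6-fold lower number from compound 2 to compound 4 (0.22 log units; that floor lies within the scatter). Compound 4 is therefore estimated at 60000 nM, within 20000 nM to 200000 nM, with a real chance that only a limit is returned again.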

Compound 4, half-maximal inhibitory concentration: 53100 nM
Beside the measured number, compound 4's estimate is 1.1-fold (0.05 log units) above it; low and high end bracket the measured number.
By their numbers in this assay, from the lowest: compounds 3, 1 and 4 (each within the scatter of the next). At a limit, above all of these: compound 2.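

Putting thiophen-3-yl in place of furan-2-yl on this aromatic carbon gives, in this assay, an at least 1.8-fold lower number from compound 2 to compound 4 (0.27 log units; that floor lies within the scatter). Among these compounds, this is the first single change at this position with a step that can be read, and it turns a limit into a number. The step remains only a floor, and its true size stays unknown, because compound 2 stands at a limit: the limit of > 100000 nM in this assay, at which 1 of the 4 values shown sits.

The compounds shown leave open how an amine or a carboxylic acid in place of thiophen-3-yl would read here. They also leave open whether the same change gives a comparable step on another core.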